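A few compounds are considered here, and "the series" means these few. Any claim that something is new, unique, unknown or untested is made for them only; others in the source may bear on it.

Within the data shown here, compound 1 `CCCCCCCCS(=O)(=O)Nc1cc(-c2ccccc2OC)ccc1C(=O)O` gives 16100 nM in an assay on mitochondria (strain BALB/c) for inhibition of glycerol-3-phosphate acyltransferase 1, mitochondrial (Mus musculus), read by scintillation counting, with a stated time of 10 min (on this read-out higher numbers stand for weaker inhibition and lower numbers for stronger inhibition), the lowest of the three numbers measured so far. Compound 3 `CCCCCCCCS(=O)(=O)Nc1ccc(/C=C/c2ccccc2)cc1C(=O)O` gives 16300 nM, within the scatter of compound 1, while compound 2 `CCCCCCCCS(=O)(=O)Nc1ccc(-c2ccccc2O)cc1C(=O)O` gives 61700 nM, the furthest away. Compound 4 `CCCCCCCCS(=O)(=O)Nc1cc(CCc2ccccc2)ccc1C(=O)O` differs from compound 1 by phenethyl in place of 2-methoxyphenyl on an aromatic carbon. Among the measured compounds shown here, the one step that bears on this swap, exchanging an aromatic ring for a two-carbon-linked phenyl, is a 3.8-fold lower number from compound 2 to compound 3 (0.58 log units; beyond the scatter), a modest drop. Since compound 1 already sits beside compound 3 on 16300 nM, only a small shift is expected, estimated as a 1.2-fold lower number from compound 1 to compound 4 (0.06 log units; within the scatter). Compound 4 is therefore estimated at 14000 nM, with a range from 5000 nM to 40000 nM.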

Compound 4, half-maximal inhibitory concentration: 37500 nM
Compound 4: middle estimate off by 2.7-fold (0.43 log units), on the low side, and the stated range covers the measured number.
By their numbers in this assay, from the lowest: compounds 1 and 3 (each within the scatter of the next); then compounds 4 and 2 (each within the scatter of the next).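

At this place, para to a carboxy group, the exchange is not neutral: phenethyl in place of 2-methoxyphenyl gives a 2.3-fold higher number from compound 1 to compound 4 (0.37 log units; beyond the scatter), although both groups have 8 heavy atoms and one aromatic ring. The earlier step, a 3.8-fold lower number from compound 2 to compound 3 (0.58 log units; beyond the scatter), ran the other way, but with different groups leaving and entering. The change also removes the one hydrogen-bond acceptor of the leaving group, and nothing available explains the rise. From the compounds shown here alone, whether an unsubstituted phenyl or a benzyl group at this carbon would track compound 1 or compound 4 remains open.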